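Quinuclidinyl triazoles: fluoro added to the benzyloxy group

A few compounds are considered here, and "the series" means these few. Any claim that something is new, unique, unknown or untested is made for them only; others in the source may bear on it.

Measured so far:
- compound 1 `Fc1cccc(-c2cn([C@@H]3CN4CCC3CC4)nn2)c1`: 2.25 nM
- compound 2 `c1ccc(COc2cccc(-c3cn([C@@H]4CN5CCC4CC5)nn3)c2)cc1`: 6.67 nM
- compound 3 `c1ccc(COc2cccc(-c3cn(C4CN5CCC4CC5)nn3)c2)cc1`: 7.57 nM

All three compounds were tested in an assay on HEK293 cells for displacement of a labelled ligand from Neuronal acetylcholine receptor; alpha3/beta4 (Homo sapiens), read by scintillation counting, with a stated time of 120 min; a lower number here means a stronger inhibitor, a higher number a weaker inhibitor. Compound 2 sits apart from compound 1 by a 3.0-fold higher number from compound 1 to compound 2 (0.47 log units; beyond the scatter), a benzyloxy in place of fluoro on an aromatic carbon. Compound 2 and compound 3 give values within the scatter of each other a 1.1-fold higher number from compound 2 to compound 3 (0.05 log units; within the scatter); the two share all atoms and bonds, and the only difference is the fact that one of compounds 2 and 3 is drawn with a defined configuration and the other without, at the place where they differ.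

Compound 4 `Fc1ccc(COc2cccc(-c3cn([C@@H]4CN5CCC4CC5)nn3)c2)cc1` differs from compound 2 by fluoro in place of hydrogen on an aromatic carbon of a six-membered aromatic ring of carbon only, para to a large group. Read one bond further out, this is benzyloxy becoming (4-fluorobenzyl)oxy.

Within the data shown here, no measured step changes this position. Among the measured compounds shown here, the one substituent step on record, from compound 1 to compound 2, concerns the other ring and a much larger group, and the step from compound 2 to compound 3 concerns drawn configuration only. For the measured compounds named here, with a single fluorine atom entering and no comparable precedent, a step no larger than the scatter is expected for compound 4 in this assay, a 1.0-fold higher number from compound 2 to compound 4 (0.02 log units; within the scatter). Compound 4 is therefore estimated at 7 nM, within 3 nM to 16 nM.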

Compound 4, inhibition constant: 7.17 nM
For compound 4 the middle estimate is 1.0-fold (0.01 log units) below the measured one; measured number inside the range.
By their numbers in this assay, from the lowest: compound 1; then compounds 2, 4 and 3 (each within the scatter of the next).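

In this assay, among these compounds, the change from benzyloxy to (4-fluorobenzyl)oxy gives a 1.1-fold higher number from compound 2 to compound 4 (0.03 log units; within the scatter) and offers the first reading on the phenyl of the benzyloxy group: with a fluoro on the aromatic carbon para to a large group, compound 2 and compound 4 cannot be told apart. The larger group's separation from compound 1 remains with the fluorine in place, at a 3.2-fold higher number from compound 1 to compound 4 (0.50 log units; beyond the scatter) and in the same modest class as a 3.0-fold higher number from compound 1 to compound 2 (0.47 log units; beyond the scatter) on the record for the unsubstituted benzyloxy group. Nothing on record offers an explanation for the result at this position.

Open, on these data alone, is whether a single fluoro stands for this position as a whole: chloro, methoxy, trifluoromethyl, nitrile or an amine at the same carbon could still give a step beyond the scatter, and fluoro on the other aromatic carbons of that ring remains unread. Also open, as far as these compounds go, is how a longer chain in place of the benzyl group would read, and whether the (4-fluorobenzyl)oxy compound keeps its value when its stereocentre is drawn with the opposite configuration.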